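The compounds below may be only part of what the source reports. "The series", "measured", "known", "first", "only" and "open" are said of these compounds alone.

Of the compounds shown here, three have been measured in a functional assay for antagonist activity at Alpha-1A adrenergic receptor (Oryctolagus cuniculus); on this read-out lower numbers stand for tighter binding and higher numbers for weaker binding. Compound 1 `CNC(=O)c1cccnc1NCCCN1CCN(c2ccccc2OC)CC1` gives 1 nM, compound 2 `COc1ccccc1N1CCN(CCCSc2ccccc2C(=O)N(C)C)CC1` gives 2 nM, and compound 3 `CN(C)C(=O)c1cccnc1NCCCN1CCN(c2ccccc2O)CC1` gives 5.01 nM, the highest of the three numbers; its gaps to compound 2 and to compound 1 both lie beyond the usual scatter. Compound 4 `COc1cc(C)ccc1N1CCN(CCCNc2ncccc2C(=O)N(C)C)CC1` has not yet been measured. It differs from compound 3 in one place: 2-methoxy-4-methylphenyl in place of 2-hydroxyphenyl on an amine nitrogen in a ring. Where compound 3 carries 2-hydroxyphenyl, compound 1 carries a methoxy-bearing phenyl and gives 1 nM, the lowest number seen, so a lower number is expected for compound 4. The step expected here is a 2.5-fold lower number from compound 3 to compound 4 (0.40 log units; beyond the scatter), downward. Compound 4 is estimated at 2 nM, within a range from 0.7 nM to 6 nM.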

Compound 4, dissociation constant: 0.794 nM
Beside the measured number, compound 4's estimate is 2.5-fold (0.40 log units) above it, and the stated range covers the measured number.
By their numbers in this assay, from the lowest: compounds 4, 1 and 2 (each within the scatter of the next, the first and the last beyond it); then compound 3.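

This position on the ring amine nitrogen now has its first direct comparison: replacing 2-hydroxyphenyl with 2-methoxy-4-methylphenyl gives a 6.3-fold lower number from compound 3 to compound 4 (0.80 log units; beyond the scatter). The change removes the hydrogen-bond donor and adds two heavy atoms, so the lower number cannot be assigned to the methoxy or the methyl alone. No available evidence explains the step. The compounds shown leave open how the shared core would respond to the methoxy without the methyl. They also leave open how it would respond to an ethoxy group or a chlorine atom in the methoxy's place.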